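The compounds below may be only part of what the source reports. "The series", "measured", "known", "first", "only" and "open" are said of these compounds alone.

In a functional assay on PC-3 cells (Homo sapiens) for cytotoxicity, read by MTT assay, with a stated time of 24 h (on this read-out lower numbers stand for stronger inhibition and higher numbers for weaker inhibition), compound 1 `COc1ccc(/C=C2\CN(C(=S)SCc3cn(Cc4ccccc4Cl)nn3)C/C(=C\c3ccc(OC)cc3)C2=O)cc1` gives 60100 nM, the higher of the two numbers measured in this series. Compound 2 `Cc1ccc(/C=C2\CN(Cc3cn(Cc4ccccc4F)nn3)C/C(=C\c3ccc(C)cc3)C2=O)cc1` gives 8800 nM in this assay, and the gap to compound 1 lies beyond the usual scatter. For compound 3 `Cc1ccc(/C=C2\CN(C(=S)SCc3cn(Cc4cccc(Cl)c4)nn3)C/C(=C\c3ccc(C)cc3)C2=O)cc1` this assay reports only a limit, > 80000 nM; this is the limit of > 80000 nM in this assay, at which 1 of the 3 values shown sits.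

Compound 4 `COc1ccc(/C=C2\CN(C(=S)SCc3cn(Cc4ccccc4F)nn3)C/C(=C\c3ccc(OC)cc3)C2=O)cc1` differs from compound 1 by fluoro in place of chloro on an aromatic carbon. Among the compounds with values here, no measured pair carries this exchange on its own, so the step is expected to be small: the change in this assay a 1.1-fold lower number from compound 1 to compound 4 (0.04 log units; within the scatter) is expected to stay within the scatter. Compound 4 is therefore estimated at 55000 nM in this assay, with a range from 25000 nM to 80000 nM.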

Compound 4, half-maximal inhibitory concentration: 31500 nM
The estimate for compound 4 lay 1.7-fold (0.24 log units) above the measured number, within the range that was stated.
By their numbers in this assay, from the lowest: compound 2; then compounds 4 and 1 (each within the scatter of the next). At a limit, above all of these: compound 3.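

In this assay, within the data shown here, the first step that changes one place only is a 1.9-fold lower number from compound 1 to compound 4 (0.28 log units; within the scatter). On the aromatic carbon ortho to a large group, chloro and fluoro therefore cannot be told apart on this read-out, at least on the core of compound 1. No measured property on record bears on this step.

On these data alone, it remains open whether an amine or a carboxylic acid at this position would move the number beyond the scatter. The same exchange is also untested here on any other core, including that of compound 3.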